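The compounds below may be only part of what the source reports. "The series", "measured", "known", "first", "only" and "open" are said of these compounds alone.

Compound 1 `O=C(CSc1nnc(-c2ccncc2)o1)N/N=C/c1ccc(Cl)cc1` gives 20500 nM in a functional assay on BGC-823 cells (Homo sapiens) for cytotoxicity, read by MTT assay, with a stated time of 48 h; on this read-out lower numbers stand for stronger inhibition and higher numbers for weaker inhibition. Compound 2 `O=C(CSc1nnc(-c2ccncc2)o1)N/N=C/c1ccc(Br)cc1` gives 24500 nM in this assay; the change between them, (bromo in place of chloro on an aromatic carbon), made a 1.2-fold higher number from compound 1 to compound 2 (0.08 log units; within the scatter). Compound 3 `O=C(CSc1nnc(-c2ccncc2)o1)N/N=C/c1cc(Cl)ccc1O` gives 5470 nM in this assay, and it differs from compound 1 by 5-chloro-2-hydroxyphenyl in place of 4-chlorophenyl on a carbon with a double bond to nitrogen, a step of a 3.7-fold lower number from compound 1 to compound 3 (0.57 log units; beyond the scatter). Compound 4 `O=C(CSc1nnc(-c2ccncc2)o1)N/N=C/c1cc(Br)ccc1O` has not yet been measured; it differs from compound 3 by bromo in place of chloro on an aromatic carbon. Going by the values given here, this is the same kind of change as the one from compound 1 to compound 2, but the place is not the same: in compound 1 the group sits para to a large group, whereas in compound 3 it sits meta to a large group and para to a hydroxy group. Because a 1.2-fold higher number from compound 1 to compound 2 (0.08 log units; within the scatter) stayed within the scatter, compound 4 is expected to shift only slightly, a 1.2-fold higher number from compound 3 to compound 4 (0.06 log units; within the scatter). Compound 4 is therefore estimated at 6300 nM in this assay, between 3000 nM and 13000 nM.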

Compound 4, half-maximal inhibitory concentration: 9590 nM
Compound 4: the middle estimate sits 1.5-fold (0.18 log units) below what was measured; low and high end bracket the measured number.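

In this assay, bromo in place of chloro on an aromatic carbon gave steps of similar size on the two cores: the same change on two cores in this assay, a 1.2-fold higher number (0.08 log units; within the scatter) from compound 1 to compound 2 and a 1.8-fold higher number (0.24 log units; within the scatter) from compound 3 to compound 4, 1.5-fold (0.17 log units) apart, within the scatter of two such steps. On the hydroxy-bearing core the step is a 1.8-fold higher number from compound 3 to compound 4 (0.24 log units; within the scatter), so the small shift carried over, and the 5-bromo-2-hydroxyphenyl group still reads lower than either 4-halophenyl group, with a 2.6-fold lower number from compound 2 to compound 4 (0.41 log units; beyond the scatter) and a 2.1-fold lower number from compound 1 to compound 4 (0.33 log units; beyond the scatter). Going by these compounds alone, these are only two pairs with small steps, so they do not show that the change would stay this small on any other core.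

Still open, going by these compounds, is how a fluoro, a methoxy or an amine in place of the halogen would read in this assay. Also open, on these data alone, is how a methoxy in place of the hydroxy would read there.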